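The source may hold more compounds than are shown below. What is called first, only, known or untested is meant among the compounds shown, and "the series" means these compounds.

Among the compounds with values here, in a functional assay on P388 cells (Mus musculus) for antiproliferative activity (a lower number here means a stronger inhibitor, a higher number a weaker inhibitor), compound 1 `COC1=C(OCc2ccc([N+](=O)[O-])cc2)/C(=C\Cn2cnc3c(Cl)ncnc32)OC1=O` gives 6490 nM, the only actual number so far. As far as these compounds go, compound 2 `COC1=C(OC)C(O)(CCn2cnc3c(Cl)ncnc32)OC1=O` reads > 120000 nM, which is a limit of the assay and not a number, so its true position is unknown. Compound 3 `COC1=C(OC)C(O)(CCn2cnc3c(N)ncnc32)OC1=O` keeps the core of compound 2 and carries one change, amino in place of chloro on an aromatic carbon. Within the data shown here, no measured pair shows the effect of this exchange, so the expectation is weak. Among the measured compounds shown here, with no measured step to support a large gain, the expected size of an at least 1.2-fold lower number from compound 2 to compound 3 (0.07 log units; that floor lies within the scatter) is modest, towards a slightly stronger inhibitor if any change is seen, and a second reading at the limit is about as likely as a number. For compound 3, the estimated value in this assay is 100000 nM, with an expected range of 30000 nM to 300000 nM.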

Compound 3, half-maximal inhibitory concentration: > 120000 nM
Compound 3 gave a limit, no number (the forecaster's own chance of this, stated with the estimate: 55%); at least 1.2-fold (0.07 log units) between middle value and limit.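

Compound 2 and compound 3 both read as limits in this assay, so no step can be read between them: the limit of > 120000 nM in this assay, at which 2 of the 3 values shown sit.

The compounds shown leave open whether amino in place of chloro on an aromatic carbon changes activity at all, and in which direction.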